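The compounds below may be only part of what the source reports. "The series", "measured", "known", "first", "only" and "open" are said of these compounds alone.

Measured compounds in a functional assay on PC-3 cells (Homo sapiens) for inhibition, read by MTT assay, with a stated time of 72 h; a higher number here means a weaker inhibitor, a lower number a stronger inhibitor:

- compound 1, `O=C(CSc1nc(Nc2ccccc2)c2ccccc2n1)Nc1cccc(Br)c1`: 11400 nM
- compound 2, `O=C(CSc1nc(Nc2ccccc2)c2ccccc2n1)Nc1ccc(Br)cc1`: 8450 nM

Compound 2 gives the lower of the two numbers, but the step of a 1.3-fold lower number from compound 1 to compound 2 (0.13 log units; within the scatter) falls within the scatter, so the two compounds cannot be told apart on these data.

Compound 3, `O=C(CSc1nc(Nc2ccccc2)c2ccccc2n1)Nc1ccc([N+](=O)[O-])cc1`, is not yet measured. It differs from compound 2 by nitro in place of bromo on an aromatic carbon. Among the measured compounds shown here, no measured step exchanges one substituent for another of a different kind; the only step known, a 1.3-fold lower number from compound 1 to compound 2 (0.13 log units; within the scatter), moves the bromo group from one position of the ring to another and is itself within the scatter. Nothing in the series therefore points to a change beyond the scatter, and the expectation is that compound 3 stays near compound 2, with the step of a 1.1-fold lower number from compound 2 to compound 3 (0.02 log units; within the scatter) expected to be small.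

The estimate for compound 3 in this assay is 8000 nM, with a range from 3000 nM to 22000 nM.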

Compound 3, half-maximal inhibitory concentration: 25000 nM
For compound 3 the middle estimate is 3.1-fold (0.49 log units) below the measured one; the whole stated range lies below it.
By their numbers in this assay, from the lowest: compounds 2 and 1 (each within the scatter of the next); then compound 3.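

In this assay, the ring carbon para to a large group responds to the kind of substituent it carries: a 3.0-fold higher number from compound 2 to compound 3 (0.47 log units; beyond the scatter) comes with nitro in place of bromo, a modest change beyond the scatter, whereas shifting bromo on the ring had given nothing that could be read. The comparison with the other bromo compound agrees, with a 2.2-fold higher number from compound 1 to compound 3 (0.34 log units; beyond the scatter) as a modest step beyond the scatter, so compound 3 stands apart from both bromo compounds. No measurement bearing on the reason for this difference is available.

As far as these compounds go, whether the higher number is particular to nitro or extends to other groups at this carbon stays open. An amine or a carboxylic acid there, or nitro on the ring carbon that carries bromo in compound 1, would show how far the change extends.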